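From cyclobutylmethyl to isopropyl on an amide-type nitrogen

This account rests on a few compounds, and the source may have more. Where it says the series, first, only, none or still open, it means among the compounds named here.

Of the compounds shown here, two with a shared core have been tested so far in an ADME assay on Huh-7 cells (Homo sapiens) for cytotoxicity, with a stated time of 72 h (on this read-out higher numbers stand for lower toxicity in this test and lower numbers for higher toxicity in this test), and neither gives an exact number. Compound 1 (`CS(=O)(=O)Nc1ccc2c(c1)S(=O)(=O)N=C(C1=C(O)C3CCCC3N(C3CCCCC3)C1=O)N2`) carries cyclohexyl on an amide-type nitrogen in a ring and gives > 10000 nM as its result, which is a limit of the assay. Compound 2 (`CS(=O)(=O)Nc1ccc2c(c1)S(=O)(=O)N=C(C1=C(O)C3CCCC3N(CC3CCC3)C1=O)N2`) carries cyclobutylmethyl there and gives > 33000 nM as its result, again a limit, and this is all that is known of where it stands. Within the data shown here, the one measured step is a step that the two limits leave unreadable from compound 1 to compound 2 and offers no size to carry forward.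

Compound 3 (`CC(C)N1C(=O)C(C2=NS(=O)(=O)c3cc(NS(C)(=O)=O)ccc3N2)=C(O)C2CCCC21`) has isopropyl in place of cyclobutylmethyl on that nitrogen (isopropyl in place of cyclobutylmethyl on an amide-type nitrogen in a ring). Like the group it replaces, isopropyl has no hydrogen-bond donors, no acceptors and no net charge. With compound 2 at > 33000 nM as the only reference, no step beyond the scatter is expected in this assay and no direction can be favoured. The expected outcome is a number no higher from compound 2 to compound 3 (the limit leaves the size open) in size. Compound 3 is estimated at 33000 nM with an expected range from 10000 nM to 100000 nM as its likely span.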

Compound 3, half-maximal cytotoxic concentration: > 33000 nM
Compound 3 ended at the assay's limit (the forecaster's own chance of this, stated with the estimate: 85%); the middle value lies on the limit itself.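

In this assay, no step can be read among compound 1, compound 2 and compound 3, because all three results are limits of the assay and not numbers: the limit of > 33000 nM in this assay, at which 2 of the 3 values shown sit. As far as these compounds go, whether cyclohexyl, cyclobutylmethyl and isopropyl on that nitrogen differ at all in this read-out stays open, as does the exact value of each compound.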